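A few compounds are considered here, and "the series" means these few. Any claim that something is new, unique, unknown or untested is made for them only; others in the source may bear on it.

Compound 1 `c1cncc(CN[C@H]2C3C4CC5C6C4CC3C6C52)c1` gives 508 nM in an assay on brain for displacement of a labelled ligand from Sigma non-opioid intracellular receptor 1 (Rattus norvegicus); a lower number here means a stronger inhibitor, a higher number a weaker inhibitor.
Compound 2 `CN(Cc1ccccc1)[C@H]1C2C3CC4C5C3CC2C5C41` gives 770 nM in this assay.
Compound 3 `COc1ccc(CN(C)[C@H]2C3C4CC5C6C4CC3C6C52)cc1OC` gives 255 nM in this assay.

Compound 2 has the highest of these three numbers. Its gap to compound 1 lies within the usual scatter, so the two cannot be told apart; compound 3 sits clearly lower, beyond the scatter. Compound 4 `CN(Cc1cccnc1)[C@H]1C2C3CC4C5C3CC2C5C41` is not yet measured. It differs from compound 2 in one place: pyridin-3-yl in place of phenyl on a saturated chain carbon bound to an amine nitrogen. Going by the values given here, no measured pair shows this exact change, so the size of the step is uncertain. The expected step, a 1.3-fold lower number from compound 2 to compound 4 (0.11 log units; within the scatter), is small, none beyond the scatter, in either direction. Compound 4 is therefore expected to give about 600 nM in this assay, with a range from 250 nM to 1400 nM.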

Compound 4, inhibition constant: 970 nM
Beside the measured number, compound 4's estimate is 1.6-fold (0.21 log units) below it, and the stated range covers the measured number.
By their numbers in this assay, from the lowest: compounds 3, 1, 2 and 4 (each within the scatter of the next, the first and the last beyond it).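

In this assay the first direct test of pyridin-3-yl in place of phenyl on a saturated chain carbon bound to an amine nitrogen gives a 1.3-fold higher number from compound 2 to compound 4 (0.10 log units; within the scatter) and so shows no change that can be told from scatter. Methyl in place of hydrogen on the amine nitrogen gives a 1.9-fold higher number from compound 1 to compound 4 (0.28 log units; within the scatter) and is likewise no clear change. No supporting data explain either result.

As far as these compounds go, whether pyridin-2-yl or pyridin-4-yl would behave the same remains open. So does the effect of an ethyl group on the amine nitrogen.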